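This account rests on a few compounds, and the source may have more. Where it says the series, first, only, none or still open, it means among the compounds named here.

The series is built on the core of compound 1 `O=[N+]([O-])c1ccccc1NC(CO)CO`. In a functional assay on SK-BR-3 cells (Homo sapiens) for cytotoxicity (a lower number here means a stronger inhibitor, a higher number a weaker inhibitor), compound 1 gives > 100000 nM, a limit of the assay rather than a number. Compound 2 `O=[N+]([O-])c1ccc(NC(CO)CO)c([N+](=O)[O-])c1` likewise returns only a limit, > 100000 nM, in this assay. Compound 3 `O=[N+]([O-])c1cc(C(F)(F)F)ccc1NC(CO)CO` also stops at a limit, > 100000 nM. The steps a step that the two limits leave unreadable from compound 1 to compound 2, a step that the two limits leave unreadable from compound 1 to compound 3 and a step that the two limits leave unreadable from compound 2 to compound 3 cannot be sized, since all three values sit at the same limit (the limit of > 100000 nM in this assay, at which 3 of the 3 values shown sit). Compound 4 `O=[N+]([O-])c1ccc(NC(CO)CO)c(C(F)(F)F)c1` differs from compound 2 by trifluoromethyl in place of nitro on an aromatic carbon. Among the compounds with values here, no measured step offers a readable size for this change, and every value shown rests on the limit (the limit of > 100000 nM in this assay, at which 3 of the 3 values shown sit). Compound 4 is accordingly expected to remain at or near that limit, with an estimated step of a number no higher from compound 2 to compound 4 (the limit leaves the size open) and an expected 100000 nM in this assay, ranging from 30000 nM to 300000 nM.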

Compound 4, half-maximal inhibitory concentration: > 100000 nM
Compound 4 ended at the assay's limit; the forecaster's own chance of this, stated with the estimate: 85%; the middle value sits exactly at the limit.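

No new step can be read between compound 2 and compound 4, since both stop at a limit in this assay: the limit of > 100000 nM in this assay, at which 4 of the 4 values shown sit.

The compounds shown leave open how far the four differ, and which change to the shared core, if any, would give a readable value in this assay.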